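A few compounds are considered here, and "the series" means these few. Any claim that something is new, unique, unknown or untested is made for them only; others in the source may bear on it.

Measured so far:
- Compound 1 `COc1cnc(-c2ccccn2)nc1C1CCCC1`: 1800 nM
- Compound 2 `COc1cnc(-c2ccccn2)nc1NCc1ccccc1`: 420 nM

In a functional assay on RAW264.7 cells (Mus musculus), with a stated time of 3 days (a lower number here means a stronger inhibitor, a higher number a weaker inhibitor), compound 2 gives 420 nM, the lower of the two numbers and so the stronger inhibitor. Compound 1 gives 1800 nM, a gap beyond the usual scatter of repeat measurements.

Compound 3 `COc1cnc(-c2ccccn2)nc1NC1CCCC1` has not yet been measured. It differs from compound 2 in one place, with cyclopentyl in place of benzyl on a nitrogen on an aromatic ring.

Going by the values given here, no measured pair differs in just one place, so the data offer no direct guide to this swap, and any forecast is rough. Compound 3 keeps the nitrogen of compound 2, which gives 420 nM, and it shares the cyclopentyl of compound 1, which gives 1800 nM. A value between these two, nearer to that of compound 2, therefore seems the most likely outcome. The expected change is a small move toward a higher number, perhaps none beyond the scatter: a 1.5-fold higher number from compound 2 to compound 3 (0.19 log units; within the scatter). The estimate for compound 3 is 650 nM, with an expected range of 200 nM to 2000 nM.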

Compound 3, half-maximal inhibitory concentration: 570 nM
The estimate for compound 3 lay 1.1-fold (0.06 log units) above the measured number; measured number inside the range.
By their numbers in this assay, from the lowest: compounds 2 and 3 (each within the scatter of the next); then compound 1.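

In this assay, cyclopentyl in place of benzyl on a nitrogen on an aromatic ring gives a 1.4-fold higher number from compound 2 to compound 3 (0.13 log units; within the scatter), so at this position the assay does not separate a five-membered non-aromatic carbon ring from the benzyl group with its six-membered aromatic ring. Going by these compounds alone, the new compound also gives the first direct look at the nitrogen itself: cyclopentylamino in place of cyclopentyl on an aromatic carbon gives a 3.2-fold lower number from compound 1 to compound 3 (0.50 log units; beyond the scatter), a modest step and, of the two steps read here, the only one beyond the usual scatter. No measurement is available that explains either result.

These three compounds leave open how much variety the nitrogen's substituent can take, since a small methyl group, a longer chain such as 2-phenylethyl, or a ring carrying a hydroxyl or an amine could behave quite differently from benzyl and cyclopentyl. They also leave open whether the gain seen with the nitrogen holds for other groups, as it rests on the cyclopentyl pair alone, and whether an oxygen in the nitrogen's place, giving cyclopentyloxy, would do the same.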